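This account rests on a few compounds, and the source may have more. Where it says the series, first, only, none or still open, it means among the compounds named here.

Compound 1 `Cc1ccc(S/C(=C/c2ccc(Cl)c(Cl)c2)C(=O)c2ccc(Br)cc2)cc1`: 50000 nM
Compound 2 `Cc1ccc(S/C(=C/c2ccc(Cl)cc2)C(=O)c2ccc(Br)cc2)cc1`: 10000 nM
Compound 3 `Cc1ccc(S/C(=C/c2ccc(C)s2)C(=O)c2ccc(Br)cc2)cc1`: > 100000 nM (a limit of the assay, not a number)

In a functional assay on DU-145 cells (Homo sapiens) for inhibition, read by trypan blue exclusion, with a stated time of 96 h (a lower number here means a stronger inhibitor of growth, a higher number a weaker inhibitor of growth), compound 2 gives 10000 nM, the lower of the two actual numbers, and compound 1 gives 50000 nM. For compound 3, the reported > 100000 nM is a limit, as the limit of > 100000 nM in this assay, at which 1 of the 3 values shown sits, records.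

Compound 4 `Cc1ccc(S/C(=C/c2ccc(-c3ccccc3)cc2)C(=O)c2ccc(Br)cc2)cc1` differs from compound 2 in one place: phenyl in place of chloro on an aromatic carbon. The new phenyl sits para to a large group.

Going by the values given here, two measured steps bear on this, as both alter the same aryl group of compound 2. One is a 5.0-fold lower number from compound 1 to compound 2 (0.70 log units; beyond the scatter), and the other is an at least 10-fold higher number from compound 2 to compound 3 (1.00 log units; beyond the scatter). Among the compounds with values here, in both, compound 2 holds the lower number, and no measured compound goes against this. Neither step places a phenyl there, so the guidance is only indirect.

A modest rise is therefore expected, and the estimated step is a 3.0-fold higher number from compound 2 to compound 4 (0.48 log units; beyond the scatter). Compound 4 is expected to give 30000 nM, with an estimated range from 8000 nM to 100000 nM.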

Compound 4, concentration for 50% growth inhibition: 50000 nM
For compound 4 the middle estimate is 1.7-fold (0.22 log units) below the measured one, within the range that was stated.
By their numbers in this assay, from the lowest: compound 2; then compounds 1 and 4 (each within the scatter of the next). At a limit, above all of these: compound 3.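

In this assay, phenyl in place of chloro on this aromatic carbon, para to a large group, brings a 5.0-fold higher number from compound 2 to compound 4 (0.70 log units; beyond the scatter). The earlier steps shown here changed the aryl group by adding a second chloro or by exchanging the whole ring for 5-methylthiophen-2-yl, whereas this step changes the 4-substituent itself, showing that a six-carbon aromatic ring at this carbon gives a higher number than chloro but still a measured one. Going by these compounds alone, compound 3 remains the only compound at a limit: the limit of > 100000 nM in this assay, at which 1 of the 4 values shown sits.

The compounds shown do not tell why phenyl gives a higher number than chloro, and one replacement cannot establish a trend at this carbon. On these data alone, what an amine, a methoxy group or a carboxylic acid would give there remains open, as does the effect of changes to the bromophenyl or methylphenyl parts, which all four compounds share.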